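The compounds below may be only part of what the source reports. "The series", "measured", "known", "first", "only" and "open" are said of these compounds alone.

Measured compounds, with binding in an assay on CHO cells for displacement of a labelled ligand from 5-hydroxytryptamine receptor 1D (Homo sapiens); a lower number here means a stronger inhibitor, a higher number a weaker inhibitor:
- compound 1, `CN(CC1CCN(CCCc2c[nH]c3ccc(-n4cnnc4)cc23)CC1)C(=O)Nc1ccccc1`: compound 1 gives 5.9 nM
- compound 2, `c1ccc(C2CCCCN2C2CCN(CCCc3c[nH]c4ccc(-n5cnnc5)cc34)CC2)cc1`: compound 2 gives 1.9 nM
- compound 3, `CN(Cc1cccs1)C1CCN(CCCc2c[nH]c3ccc(-n4cnnc4)cc23)CC1`: compound 3 gives 4.3 nM

Compound 3 holds the second highest of the three numbers. Its nearest neighbour is compound 1, whose number sits slightly higher, a gap that falls within the usual scatter of this assay, so no order between compound 3 and compound 1 can be read from these two values. The furthest is compound 2, whose number lies lower than that of compound 3 by a margin beyond the scatter. Among the compounds with values here, no pair among the three differs in a single place, so none of these gaps can be assigned to one structural change.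

Compound 4, `CN(Cc1ccsc1)C1CCN(CCCc2c[nH]c3ccc(-n4cnnc4)cc23)CC1`, has not yet been measured. It differs from compound 3 in one place: thiophen-3-yl in place of thiophen-2-yl on a saturated chain carbon bound to an amine nitrogen. The two compounds share every atom; only the point at which the five-membered aromatic ring is joined to the saturated chain carbon moves.

Within the data shown here, nothing among the measured compounds speaks to this kind of change, and the rest of the molecule is kept whole. The expectation is therefore a step of a 1.0-fold higher number from compound 3 to compound 4 (0.02 log units; within the scatter) in this assay, with no direction favoured and no shift beyond the scatter anticipated. Compound 4 is estimated at 4.5 nM, within a range of 1.8 nM to 11 nM.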

Compound 4, half-maximal inhibitory concentration: 1.5 nM
The estimate for compound 4 lay 3.0-fold (0.48 log units) above the measured number; the measured number lies below the stated range.
By their numbers in this assay, from the lowest: compounds 4 and 2 (each within the scatter of the next); then compounds 3 and 1 (each within the scatter of the next).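

In this assay, the point at which the five-membered aromatic ring is joined to the saturated chain carbon bound to an amine nitrogen matters: thiophen-3-yl in place of thiophen-2-yl gives a 2.9-fold lower number from compound 3 to compound 4 (0.46 log units; beyond the scatter), even though the two groups have the same heavy atoms, the same hydrogen-bond donor and acceptor counts and no net charge. Within the data shown here, this is the first single-place step, and it shows that moving the attachment point alone, with no atom added or removed, can shift the number beyond the scatter, though the step is modest and rests on one pair. Nothing available accounts for the size or direction of this step.

On these data alone, whether the same order of the two attachment points holds for other rings on this carbon, such as furan-2-yl against furan-3-yl, remains open, as does how phenyl or pyridin-3-yl would compare with thiophen-3-yl. Also open, as far as these compounds go, is whether the methyl of the methyl((thiophen-3-yl)methyl)amino group could give way to an ethyl without losing the number seen for compound 4.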